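The source may report more compounds than this note shows. Statements on the series, on what has been measured and on what is new or still open speak of the compounds shown alone.

In an ADME assay on HepG2 cells (Homo sapiens) for cytotoxicity, read by MTT assay, with a stated time of 48 h (on this read-out lower numbers stand for stronger inhibition and higher numbers for weaker inhibition), compound 1 `O=S(=O)(c1ccc(-c2ccc3ncnc(Nc4ccc(O)c(Cl)c4)c3c2)cc1)N1CCOCC1` gives > 15000 nM as a limit of the assay, not a number. Compound 2 `COc1cccc(COc2ccc(Nc3ncnc4ccc(-c5ccc(S(=O)(=O)N6CCOCC6)cc5)cc34)cc2Cl)c1` gives > 15000 nM and this too is only a limit, so it offers no number to start from. The data so far come down to the limit of > 15000 nM in this assay, at which 2 of the 2 values shown sit, and nothing finer. Compound 3 `O=S(=O)(c1ccc(-c2ccc3ncnc(Nc4ccc(OCc5cc(F)cc(F)c5F)c(Cl)c4)c3c2)cc1)N1CCOCC1` differs from compound 2 in one place: 2,3,5-trifluorophenyl in place of 3-methoxyphenyl on a saturated chain carbon bound to an oxygen on an aromatic ring. Within the data shown here, the one measured step, a step that the two limits leave unreadable from compound 1 to compound 2, puts 3-methoxybenzyl in place of hydrogen on an oxygen on an aromatic ring and has no size to carry forward, so no step beyond the scatter is expected in this assay and no direction can be named. The estimated step is a step that the limit leaves unreadable from compound 2 to compound 3. The estimate for compound 3 is 20000 nM, with an expected range from 10000 nM to 40000 nM.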

Compound 3, half-maximal inhibitory concentration: > 3000 nM
Compound 3: only a limit was reported (the forecaster's own chance of this, stated with the estimate: 75%); the middle value is on the limit's open side.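

No step can be read among compound 1, compound 2 and compound 3, since all three values are limits of the assay and not numbers. Left open is the actual value of each compound in this assay, and whether 2,3,5-trifluorophenyl in place of 3-methoxyphenyl changes it at all.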